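This account rests on a few compounds, and the source may have more. Where it says the series, first, only, none or still open, it means among the compounds named here.

Measured so far in an ADME assay on the whole organism for cytotoxicity, with Artemia salina as the target, with a stated time of 24 h; a higher number here means that more compound is needed for the effect, a lower number that less compound is needed: compound 1 `Cc1ccc(/C=C/C(=O)c2ccccc2NC(=O)NS(=O)(=O)c2ccc(C)cc2)cc1` gives 15.3 ug/mL; compound 2 `COc1ccc(/C=C/C(=O)c2ccccc2NC(=O)NS(=O)(=O)c2ccc(C)cc2)cc1OC` gives 12.9 ug/mL; compound 3 `Cc1ccc(S(=O)(=O)NC(=O)Nc2ccccc2C(=O)/C=C/c2ccc(Cl)cc2Cl)cc1` gives 8.34 ug/mL.

Compound 3 holds the lowest of the three numbers, yet neither of its steps to the others leaves the scatter: a 1.8-fold lower number from compound 1 to compound 3 (0.26 log units; within the scatter) and a 1.5-fold lower number from compound 2 to compound 3 (0.19 log units; within the scatter). Compound 4 `Cc1ccc(S(=O)(=O)NC(=O)Nc2ccccc2C(=O)/C=C/c2ccc[nH]2)cc1` differs from compound 3 by 1H-pyrrol-2-yl in place of 2,4-dichlorophenyl on a double-bonded chain carbon bound to a double-bonded chain carbon. Within the data shown here, no measured step exchanges the aromatic ring of carbon only for a ring with a hetero atom. The two steps that vary the group on a double-bonded chain carbon bound to a double-bonded chain carbon, a 1.8-fold lower number from compound 1 to compound 3 (0.26 log units; within the scatter) and a 1.5-fold lower number from compound 2 to compound 3 (0.19 log units; within the scatter), both stayed within the scatter, so no step beyond the scatter is expected here either. Compound 4 is therefore estimated at 12 ug/mL, range 6 ug/mL to 25 ug/mL. The expected step is a 1.4-fold higher number from compound 3 to compound 4 (0.16 log units; within the scatter).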

Compound 4, concentration for half-maximal effect: 32.1 ug/mL
For compound 4 the middle estimate is 2.7-fold (0.43 log units) below the measured one, and the stated range ends below it.
By their numbers in this assay, from the lowest: compounds 3, 2 and 1 (each within the scatter of the next); then compound 4.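

In this assay the place on a double-bonded chain carbon bound to a double-bonded chain carbon now gives steps beyond the scatter: a 3.8-fold higher number from compound 3 to compound 4 (0.59 log units; beyond the scatter) and a 2.5-fold higher number from compound 2 to compound 4 (0.40 log units; beyond the scatter) and a 2.1-fold higher number from compound 1 to compound 4 (0.32 log units; beyond the scatter) all run the same way. The three substituted phenyl groups remain within the scatter of one another, and only 1H-pyrrol-2-yl, the sole five-membered aromatic ring with a hetero atom, separates from them. No data on the origin of this separation are available.

Still open, as far as these compounds go, is whether the ring size, the hetero atom or the ring hydrogen-bond donor goes with the higher number. Furan-2-yl and 1-methylpyrrol-2-yl at this place would help to separate these.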